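Swapping trifluoromethyl for methoxymethyl on a piperidine amide

A few compounds are considered here, and "the series" means these few. Any claim that something is new, unique, unknown or untested is made for them only; others in the source may bear on it.

Three compounds share one core and were measured in a functional assay on BXPC-3 cells (Homo sapiens) for inhibition, read by MTT assay, with a stated time of 7 days; on this read-out lower numbers stand for stronger inhibition and higher numbers for weaker inhibition:
Compound 1 `CCN(CC)S(=O)(=O)c1ccc(S(=O)(=O)N2CCC[C@@H](C(=O)N3CCC(O)CC3)C2)cc1` gives 4710 nM.
Compound 2 `CCN(CC)S(=O)(=O)c1ccc(S(=O)(=O)N2CCC[C@@H](C(=O)N3CCOCC3)C2)cc1` gives 790 nM.
Compound 3 `CCN(CC)S(=O)(=O)c1ccc(S(=O)(=O)N2CCC[C@@H](C(=O)N3CCC(C(F)(F)F)CC3)C2)cc1` gives 370 nM.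

Compound 3 has the lowest number of the three, and its distance to each of the other two is beyond the scatter. Compound 4 `CCN(CC)S(=O)(=O)c1ccc(S(=O)(=O)N2CCC[C@@H](C(=O)N3CCC(COC)CC3)C2)cc1` differs from compound 3 in one place: methoxymethyl in place of trifluoromethyl on a saturated ring carbon. Among the measured compounds shown here, two measured steps touch this spot. a 13-fold lower number from compound 1 to compound 3 (1.10 log units; beyond the scatter); a 2.1-fold lower number from compound 2 to compound 3 (0.33 log units; beyond the scatter). In both, the trifluoromethyl compound sits at the low end, and the earlier step of a 6.0-fold lower number from compound 1 to compound 2 (0.78 log units; beyond the scatter) shows that a ring oxygen already does better than a hydroxy group. Methoxymethyl brings an oxygen acceptor, like compound 2, but no donor, unlike compound 1, so a number between those two is expected. The step expected here is a 2.4-fold higher number from compound 3 to compound 4 (0.39 log units; beyond the scatter). Compound 4 is therefore estimated at 900 nM, with a range from 300 nM to 2800 nM.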

Compound 4, half-maximal inhibitory concentration: 1360 nM
The estimate for compound 4 lay 1.5-fold (0.18 log units) below the measured number; the measured number falls inside the stated range.
By their numbers in this assay, from the lowest: compound 3; then compounds 2 and 4 (each within the scatter of the next); then compound 1.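

At this ring carbon, methoxymethyl falls short of trifluoromethyl (a 3.7-fold higher number from compound 3 to compound 4 (0.57 log units; beyond the scatter)) yet still does better than the hydroxy group of compound 1 (a 3.5-fold lower number from compound 1 to compound 4 (0.54 log units; beyond the scatter)), so the result places it in the middle of the series. The oxygen of the methoxymethyl chain and the ring oxygen of morpholin-4-yl give numbers that cannot be told apart here (a 1.7-fold higher number from compound 2 to compound 4 (0.24 log units; within the scatter)), and both compounds stay behind compound 3. No measurement shown gives a reason for these differences.

Going by these compounds, it remains open how a plain methyl, a longer ether chain such as ethoxymethyl, an amine or a carboxylic acid would fare on this ring carbon. Whether the same order holds in other cell lines is also unknown.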